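Methoxy on the fused ring of the pyridinyl analogue

A few compounds are considered here, and "the series" means these few. Any claim that something is new, unique, unknown or untested is made for them only; others in the source may bear on it.

The series shares the core of compound 1 `Nc1nc(-c2ccccc2)nn1-c1ncnc2ccccc12`. In an assay on MCF7 cells for inhibition of Serine-protein kinase ATM (Homo sapiens), read by immunofluorescence, with a stated time of 1 h (on this read-out lower numbers stand for stronger inhibition and higher numbers for weaker inhibition), compound 1 reaches only the assay limit, giving > 40000 nM. Compound 2 `Nc1nc(-c2ccccn2)nn1-c1ncnc2ccccc12` carries pyridin-2-yl in place of phenyl, and in this assay compound 2 likewise gives only a limit, > 40000 nM. Compound 3 `COc1ccc(-c2nc(N)n(-c3ncnc4ccccc34)n2)cc1` adds a methoxy; in this assay compound 3 also returns a limit, > 40000 nM. All three values thus share one place, (the limit of > 40000 nM in this assay, at which 3 of the 3 values shown sit), so the steps a step that the two limits leave unreadable from compound 1 to compound 2, a step that the two limits leave unreadable from compound 1 to compound 3 and a step that the two limits leave unreadable from compound 2 to compound 3 cannot be sized, and compound 2 can be placed only at that limit, not ranked against the others.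

Compound 4 `COc1ccc2ncnc(-n3nc(-c4ccccn4)nc3N)c2c1` differs from compound 2 by methoxy in place of hydrogen on an aromatic carbon. For the measured compounds named here, the nearest precedent for this kind of change is a step that the two limits leave unreadable from compound 1 to compound 3, which concerns a different place and is itself unreadable between two limits. Going by the values given here, no measured step therefore gives a direction or a size for the move to compound 4.

Compound 4 is expected to remain at the limit, with an estimate of 50000 nM and a range from 15000 nM to 150000 nM. The expected step is a step that the limit leaves unreadable from compound 2 to compound 4, that is, none beyond the scatter.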

Compound 4, half-maximal inhibitory concentration: 16900 nM
Beside the measured number, compound 4's estimate is 3.0-fold (0.47 log units) above it; measured number inside the range.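

For the compounds shown here, the methoxy on the fused ring, on the aromatic carbon meta to a fused ring and para to a fused ring, gives the first readable change in this assay, an at least 2.3-fold lower number from compound 2 to compound 4 (0.37 log units; beyond the scatter). The steps among compounds 1, 2 and 3 cannot be read, so this single substitution is the only one shown whose direction is known, and that direction is toward a lower number, meaning stronger inhibition. Compound 4 is also the only compound shown with a number rather than a limit, and the rest of the set stays where it was: the limit of > 40000 nM in this assay, at which 3 of the 4 values shown sit.

As far as these compounds go, the true size of the step stays open, as does whether the same methoxy on the fused ring would move compound 1, which carries phenyl in place of pyridin-2-yl, in the same direction. Also open, from the compounds shown here alone, is how this position responds to other groups, such as an amine or a longer chain like ethoxy, and whether any of them would lower the number further than methoxy does.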